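The compounds below may be only part of what the source reports. "The series", "measured", "known", "first", "only" and "open" are said of these compounds alone.

Three compounds share one core and a short side chain on a saturated chain carbon bound to an aromatic nitrogen. Compound 1 `C[C@@H](O)CCn1nc2c(Br)c(Br)c(Br)c(Br)c2n1`, compound 2 `C[C@H](O)CCn1nc2c(Br)c(Br)c(Br)c(Br)c2n1` and compound 3 `CC(O)CCn1nc2c(Br)c(Br)c(Br)c(Br)c2n1` differ only in the configuration drawn at a stereocentre on that chain. In a functional assay on MCF7 cells (Homo sapiens) for antiproliferative activity, read by MTT assay, with a stated time of 48 h, tested at 100 uM (on this read-out lower numbers stand for a stronger effect and higher numbers for a weaker effect at the one concentration tested), compound 1 gives 0%, compound 2 gives 6% and compound 3 gives 0%, so compound 3 stands level with compound 1, the two together the lowest of the three. The steps of a number 6 percentage points higher from compound 1 to compound 2 (within the scatter), no change at the digits printed from compound 1 to compound 3 (within the scatter) and a number 6 percentage points lower from compound 2 to compound 3 (within the scatter) all lie within the scatter. Compound 4 `OCC(O)Cn1nc2c(Br)c(Br)c(Br)c(Br)c2n1` carries 1,2-dihydroxyethyl in place of 2-hydroxypropyl on a saturated chain carbon bound to an aromatic nitrogen. Going by the values given here, no measured step alters a group, so none bears directly on this change. The step of a number 3 percentage points higher from compound 3 to compound 4 (within the scatter) is therefore expected to stay within the scatter. Compound 4 is estimated at 3%, between 0% and 15%.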

Compound 4, a percentage reported as activity, at one concentration (the size of the read-out at that concentration, not a potency): 8%
For compound 4 the middle estimate is 5 percentage points below the measured one; low and high end bracket the measured number.
By their numbers in this assay, from the lowest: compounds 1, 3, 2 and 4 (each within the scatter of the next).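

In this assay the change from 2-hydroxypropyl to 1,2-dihydroxyethyl on a saturated chain carbon bound to an aromatic nitrogen gives a number 8 percentage points higher from compound 3 to compound 4 (within the scatter) and a number 2 percentage points higher from compound 2 to compound 4 (within the scatter) and a number 8 percentage points higher from compound 1 to compound 4 (within the scatter) and all three steps lie within the scatter. Going by these compounds alone, the earlier compounds differed only in configuration, whereas this is the first change of group at this position, and it leaves the read-out within the scatter of all three. Nothing measured here gives a reason for this result.

Going by these compounds, whether an amine, a carboxylic acid or a longer chain at this place would move the read-out beyond the scatter stays open. Also open, on these data alone, is whether the configuration of the 1,2-dihydroxyethyl chain matters, since compound 4 is drawn without one.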